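Methylcarbamoyl replaces methanesulfonamido on the shared core

The source may report more compounds than this note shows. Statements on the series, on what has been measured and on what is new or still open speak of the compounds shown alone.

Three analogues of the shared core have been measured in an ADME assay on the whole organism (Macaca fascicularis) for pharmacokinetics, read by LC-MS, using cassette dosing, at a dose of 1 mg/kg by the oral route; on this read-out lower numbers stand for lower exposure and higher numbers for higher exposure at the dose given. Compound 1, `CCCCN(c1nc2ccccc2o1)[C@H](C)c1ccc(-c2ccccc2-c2nnn[nH]2)cc1`, gives 29.2 nM. Compound 2, `CCCCN(c1nc2c(C(=O)O)cccc2o1)[C@H](C)c1ccc(-c2ccccc2-c2nnn[nH]2)cc1`, gives 238 nM. Compound 3, `CCCCN(c1nc2c(NS(C)(=O)=O)cccc2o1)[C@H](C)c1ccc(-c2ccccc2-c2nnn[nH]2)cc1`, gives 49.9 nM, the second highest of the three numbers. The two known steps into compound 3 differ in size: a 1.7-fold higher number from compound 1 to compound 3 (0.23 log units; within the scatter), whereas a 4.8-fold lower number from compound 2 to compound 3 (0.68 log units; beyond the scatter). The carboxy group alone produced an 8.2-fold higher number from compound 1 to compound 2 (0.91 log units; beyond the scatter).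

Compound 4, `CCCCN(c1nc2c(C(=O)NC)cccc2o1)[C@H](C)c1ccc(-c2ccccc2-c2nnn[nH]2)cc1`, carries methylcarbamoyl in place of methanesulfonamido on an aromatic carbon. Within the data shown here, no measured step covers this exchange; the carbonyl-bearing group shares only part of its character with carboxy. A modest rise is therefore expected, a 1.6-fold higher number from compound 3 to compound 4 (0.20 log units; within the scatter). Compound 4 is estimated to give 80 nM, within a range of 30 nM to 220 nM.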

Compound 4, maximal plasma concentration: 19.7 nM
For compound 4 the middle estimate is 4.1-fold (0.61 log units) above the measured one; the whole stated range lies above it.
By their numbers in this assay, from the lowest: compounds 4, 1 and 3 (each within the scatter of the next, the first and the last beyond it); then compound 2.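

Methylamino in place of hydroxy on the carbonyl carbon costs nearly all of what carboxy gained at this position on the aromatic carbon (a 12-fold lower number from compound 2 to compound 4 (1.08 log units; beyond the scatter)), so in this assay the carbonyl alone does not carry the higher number. Methylcarbamoyl also falls short of methanesulfonamido (a 2.5-fold lower number from compound 3 to compound 4 (0.40 log units; beyond the scatter)), and it leaves no clear separation from hydrogen (a 1.5-fold lower number from compound 1 to compound 4 (0.17 log units; within the scatter)). No measured evidence explains these steps.

Going by these compounds, it remains open whether an unsubstituted carbamoyl group or a methyl ester on this carbon would behave like carboxy or like methylcarbamoyl.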